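The compounds below may be only part of what the source reports. "The series", "measured", "known", "first", "only" and "open" are said of these compounds alone.

Measured so far in a functional assay on OVCAR-3 cells (Homo sapiens) for cytotoxicity, read by sulforhodamine B assay, with a stated time of 48 h; a higher number here means a weaker inhibitor of growth, a lower number a stronger inhibitor of growth:

Compound 1 `ClCc1ccc(Cn2cnc3c(Cl)ncnc32)cc1` — 3540 nM
Compound 2 `Nc1nc(Cl)c2ncn(Cc3ccc(CCl)cc3)c2n1` — 5500 nM
Compound 3 `ClCc1ccccc1Cn1cnc2c(Cl)ncnc21` — 3540 nM

Compound 3 sits level with compound 1 at the digits printed, and both are within the scatter of compound 2; no order can be drawn among the three. Compounds 1 and 3 have the same atoms joined differently; the difference between the two cores is not broken down here.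

One change is seen twice in the series. From compound 1 to compound 2 it is amino in place of hydrogen on an aromatic carbon, and the step in this assay is a 1.6-fold higher number from compound 1 to compound 2 (0.19 log units; within the scatter). The same change, (amino in place of hydrogen on an aromatic carbon), carries compound 3 to the unmeasured compound 4 `Nc1nc(Cl)c2ncn(Cc3ccccc3CCl)c2n1`; the place is identical word for word in both cases.

The step expected from compound 3 to compound 4 is a 1.6-fold higher number from compound 3 to compound 4 (0.19 log units; within the scatter), resting on compound 1 to compound 2 giving a 1.6-fold higher number from compound 1 to compound 2 (0.19 log units; within the scatter). Compound 4 is therefore estimated at 5500 nM, with a range from 2800 nM to 11000 nM.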

Compound 4, concentration for total growth inhibition: 20000 nM
Beside the measured number, compound 4's estimate is 3.6-fold (0.56 log units) below it; measured number above the stated range.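

In this assay, amino in place of hydrogen on an aromatic carbon gives a 5.6-fold higher number from compound 3 to compound 4 (0.75 log units; beyond the scatter), and the two cores do not take this change to the same extent: the same change on two cores in this assay, a 1.6-fold higher number (0.19 log units; within the scatter) from compound 1 to compound 2 and a 5.6-fold higher number (0.75 log units; beyond the scatter) from compound 3 to compound 4, 3.6-fold (0.56 log units) apart, beyond the scatter of two such steps

The size of the step therefore does not carry from the core of compound 1 to the core of compound 3, and a shared direction cannot be claimed either, since the step to compound 2 stays within the scatter. Two pairs do not show which feature of the cores sets the gap, or whether it would hold for any other change.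

Open, as far as these compounds go, is whether a methylamino or hydroxyl group in the same place would split the two cores in the same way. Also open, from the compounds shown here alone, is how either core would respond with a bromomethyl or methyl group in place of chloromethyl.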